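Taking the iodo group off compound 2

The compounds below may be only part of what the source reports. "The series", "measured", "known", "first", "only" and "open" are said of these compounds alone.

- Compound 1 `Cc1cn(/C=C/C#N)c(=O)[nH]c1=O` gives > 100000 nM as a limit
- Compound 2 `O=C/C=C/n1c(=O)c(I)cn([C@H]2C[C@H](O)[C@@H](CO)O2)c1=O` gives 300 nM as a measured number

Among the measured compounds shown here, in a functional assay on HeLa cells (Homo sapiens) for inhibition (on this read-out lower numbers stand for stronger inhibition and higher numbers for weaker inhibition), compound 2 gives 300 nM, the only true number so far. Compound 1 stands at > 100000 nM in this assay, which is a limit of the assay and not a number.

Compound 3 `O=C/C=C/n1c(=O)ccn([C@H]2C[C@H](O)[C@@H](CO)O2)c1=O` is compound 2 with hydrogen in place of iodo on an aromatic carbon. For the measured compounds named here, no measured pair of compounds shows what this swap does, so any forecast is uncertain. Going by the values given here, with compound 2 at 300 nM as the only starting number, a moderate loss of inhibition in this assay is expected, larger than the usual scatter. The expected change is a 5.0-fold higher number from compound 2 to compound 3 (0.70 log units; beyond the scatter), towards weaker inhibition. For compound 3 the estimated value is 1500 nM, with an expected range from 300 nM to 10000 nM as the upper end.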

Compound 3, half-maximal inhibitory concentration: 800 nM
For compound 3 the middle estimate is 1.9-fold (0.27 log units) above the measured one, within the range that was stated.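

Compound 3 gives the first measured view of this aromatic carbon. In this assay the swap of iodo for hydrogen brings a 2.7-fold higher number from compound 2 to compound 3 (0.43 log units; beyond the scatter) and so costs only a modest part of the inhibition. Compound 3 still reaches 800 nM in this assay without any heavy atom at this position, so in this pair the iodo group is not needed for inhibition in the nanomolar range, and nothing shown gives a measured reason for the size of this step.

Going by these compounds, only iodo and hydrogen can be compared here, so it remains open how a chlorine atom, an amine or a longer chain at this carbon would behave. The 2-formylethenyl group stays the same in this pair, which leaves open what replacing it with a carboxylic acid would do.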